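The source may report more compounds than this note shows. Statements on the series, on what has been measured and on what is new or still open speak of the compounds shown alone.

Compound 1 (`COC1=C(OCc2ccc([N+](=O)[O-])cc2)/C(=C\Cn2cnc3c(Cl)ncnc32)OC1=O`) and compound 2 (`COC1=C(OCc2ccc([N+](=O)[O-])cc2)C(=O)O/C1=C/Cn1cnc2c(Cl)ncnc21`) have both been tested in a functional assay on MOLT-4 cells (Homo sapiens) for antiproliferative activity; a lower number here means a stronger inhibitor, a higher number a weaker inhibitor. Here compound 1 gives 7350 nM, and compound 2 gives 6160 nM. These two numbers lie within the usual scatter of repeated measurements, so compound 2 stands level with compound 1, and the data do not separate them.

Compound 3 (`O=C1O/C(=C/Cn2cnc3c(Cl)ncnc32)C(OCc2ccc([N+](=O)[O-])cc2)=C1OCc1ccc([N+](=O)[O-])cc1`) has not yet been measured. It differs from compound 2 in one place: 4-nitrophenyl in place of hydrogen on a saturated chain carbon bound to an oxygen on an unsaturated carbon. In plain terms, 4-nitrophenyl takes the place of hydrogen on a saturated chain carbon bound to an oxygen on an unsaturated carbon, which turns the methoxy of compound 2 into (4-nitrobenzyl)oxy. That same group name already applies elsewhere in compound 2.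

Within the data shown here, no measured pair shows what this kind of change does in this assay, so any expectation here is loose. A modest move toward a lower number seems the most likely outcome, though it may not exceed the scatter. The expected size of the change is a 1.4-fold lower number from compound 2 to compound 3 (0.14 log units; within the scatter). For compound 3 the estimated value is 4500 nM, with an expected range from 1200 nM to 18000 nM.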

Compound 3, half-maximal inhibitory concentration: > 120000 nM
Compound 3 was reported as a limit; the forecaster's own chance of this, stated with the estimate: 15%; middle value at least 26-fold (1.42 log units) from the limit.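

In this assay, compound 3 is reported only as a limit of the assay, not as a number: the limit of > 120000 nM in this assay, at which 1 of the 3 values shown sits. The earlier compounds shown here carried methoxy at this place and so said nothing about whether it tolerates change, but replacing that methoxy with (4-nitrobenzyl)oxy brings an at least 19-fold higher number from compound 2 to compound 3 (1.28 log units; beyond the scatter). The other methoxy compound gives the same picture, with an at least 16-fold higher number from compound 1 to compound 3 (1.21 log units; beyond the scatter), so in this assay the place is far from indifferent to the group it carries, even though the same (4-nitrobenzyl)oxy group already stands elsewhere in the molecule without ruling out a measurable value.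

With only methoxy and (4-nitrobenzyl)oxy at this place, the compounds shown leave open whether an ethoxy, a plain benzyloxy without the nitro group, or a hydroxyl would stay level with compound 2 or fall away like compound 3. They also cannot tell which part of the added 4-nitrophenyl matters, or how much activity any intermediate group would keep.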